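The source may report more compounds than this note shows. Statements on the series, on what has been measured and on what is new or still open speak of the compounds shown alone.

Of the compounds shown here, three have been measured in a functional assay on PC-3 cells (Homo sapiens) for inhibition, read by sulforhodamine B assay, with a stated time of 48 h, tested at 50 uM; a higher number here means more inhibition of growth at the concentration tested, a lower number less inhibition of growth. Compound 1 `O=C1C(=O)N(CCCCn2cc(COc3cc(=O)oc4ccccc34)nn2)c2ccc(Br)cc21` gives 13%. Compound 2 `O=C1C(=O)N(CCCn2cc(COc3cc(=O)oc4ccccc34)nn2)c2ccc(F)cc21` gives 20%, and compound 3 `O=C1C(=O)N(CCCCn2cc(COc3cc(=O)oc4ccccc34)nn2)c2ccc(F)cc21` gives 17%. Compound 2 and compound 3 are built on different cores; the difference between the two cores is not broken down here. Compound 1 is made from compound 3 by one change: bromo in place of fluoro on an aromatic carbon. The step this made, a number 4 percentage points lower from compound 3 to compound 1 (within the scatter), lies within the usual scatter of repeated measurements, so the two numbers cannot be told apart.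

Compound 4 `O=C1C(=O)N(CCCn2cc(COc3cc(=O)oc4ccccc34)nn2)c2ccc(Br)cc21` has not yet been measured. It stands to compound 2 as compound 1 stands to compound 3: bromo in place of fluoro on an aromatic carbon. The place of the change is described in the same words for both pairs, so this is the same change carried out on the other core. Among the compounds with values here, the only guide to its size is that single earlier step, a number 4 percentage points lower from compound 3 to compound 1 (within the scatter), which stayed within the scatter. Accordingly the expected step from compound 2 to compound 4 in this assay is a number 4 percentage points lower from compound 2 to compound 4 (within the scatter), kept close to the earlier one. For compound 4 the estimated value in this assay is 16%, with a likely range from 6% to 28%. This rests on compound 2 at 20% and on the earlier step of a number 4 percentage points lower from compound 3 to compound 1 (within the scatter), a single pair, so the range is kept wide.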

Compound 4, percent growth inhibition at one concentration: 14%
For compound 4 the middle estimate is 2 percentage points above the measured one, and the stated range covers the measured number.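

On the core of compound 2, bromo in place of fluoro gives a number 6 percentage points lower from compound 2 to compound 4 (within the scatter), so the two numbers in this assay cannot be told apart. Set beside the same change on the other core, the step looks alike on both cores, and neither pair gives any sign that the core alters the outcome of the swap: the same change on two cores in this assay, a number 4 percentage points lower (within the scatter) from compound 3 to compound 1 and a number 6 percentage points lower (within the scatter) from compound 2 to compound 4, 2 percentage points apart, within the scatter of two such steps. Within the data shown here, this shows only that the swap from fluoro to bromo has carried across these two cores without any visible difference; it does not show that bromo truly lowers growth inhibition on either core, as both steps stay within the scatter, and two pairs say nothing about any other core.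

The compounds shown carry only fluoro or bromo at this aromatic carbon, so it remains open whether a different group there, such as an amine or a carboxylic acid, would shift the number by more than the scatter. From the compounds shown here alone, it also remains open whether a longer chain in place of the chain in compound 3 would do so, and whether the swap from fluoro to bromo would then behave as it does here.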